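The source may report more compounds than this note shows. Statements on the series, on what has been measured and on what is new or still open speak of the compounds shown alone.

Measured so far in an assay (Rattus norvegicus) for inhibition of Fatty-acid amide hydrolase 1 (Homo sapiens); on this read-out lower numbers stand for stronger inhibition and higher numbers for weaker inhibition:
compound 1, `COc1ccccc1-c1cnc(C(=O)CCCCCCc2ccccc2)o1`, 400 nM
compound 2, `Cc1ccc(-c2cnc(C(=O)CCCCCCc3ccccc3)o2)nc1`, 2.8 nM
compound 3, `O=C(CCCCCCc1ccccc1)c1ncc(-c2ccncn2)o1`, 2.3 nM

Compound 3 holds the lowest number of the three in this assay, but its distance to compound 2 is within the scatter (a 1.2-fold lower number from compound 2 to compound 3 (0.09 log units; within the scatter)), so the two cannot be ranked. Compound 1 sits far higher, as seen in a 170-fold lower number from compound 1 to compound 3 (2.24 log units; beyond the scatter) and a 140-fold lower number from compound 1 to compound 2 (2.15 log units; beyond the scatter).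

Compound 4, `CN(C)C(=O)c1cnc(C(=O)CCCCCCc2ccccc2)o1`, is not yet measured. Its change from compound 3 is dimethylcarbamoyl in place of pyrimidin-4-yl on an aromatic carbon. The measured steps that bear on it are those that exchange the group on this aromatic carbon: the two large steps from compound 1 show that this position can move the number by a large amount, while the step between compound 2 and compound 3 shows that two six-membered heteroaryls give numbers within the scatter. Going by the values given here, no measured step replaces a ring here by a group without a ring, so the direction rests on the loss of the aromatic ring alone. A step of moderate to large size toward a higher number is expected for compound 4, a 13-fold higher number from compound 3 to compound 4 (1.12 log units; beyond the scatter), with wide uncertainty. The estimate for compound 4 in this assay is 30 nM, with a range from 4 nM to 300 nM.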

Compound 4, inhibition constant: 2 nM
Beside the measured number, compound 4's estimate is 15-fold (1.18 log units) above it, outside the stated range (below it).
By their numbers in this assay, from the lowest: compounds 4, 3 and 2 (each within the scatter of the next); then compound 1.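

In this assay, a ring on this aromatic carbon, next to the ring oxygen, turns out not to be needed for a low number: dimethylcarbamoyl, which has no ring, cannot be separated from pyrimidin-4-yl, a 1.2-fold lower number from compound 3 to compound 4 (0.06 log units; within the scatter), or from 5-methylpyridin-2-yl, a 1.4-fold lower number from compound 2 to compound 4 (0.15 log units; within the scatter). With a 200-fold lower number from compound 1 to compound 4 (2.30 log units; beyond the scatter), a third group joins the two earlier ones in the large gap to compound 1, so among the groups shown only 2-methoxyphenyl stands apart, while compounds 2, 3 and 4 lie within the scatter of one another despite differing in ring content and in hydrogen-bond acceptor count. No measurement at hand accounts for why a group without a ring matches the two six-membered aromatic rings here.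

Open, going by these compounds, is how far this tolerance extends on the same carbon, for instance to a carboxylic acid, a primary amide, a methyl ester or a plain hydrogen. Also open, on these data alone, is whether dimethylcarbamoyl keeps pace with pyrimidin-4-yl when the chain that ends in phenyl is replaced by a shorter chain.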